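The compounds below may be only part of what the source reports. "The series", "measured", "known", "first", "only" and "open" are said of these compounds alone.

Three compounds share one core and differ only in the chain that ends in a dimethylamino group. Compound 1 `CN(C)CCCCOc1ccc2oc(-c3ccccc3)cc(=O)c2c1` gives 400 nM in an assay on isolated protein (Cavia porcellus) with Sigma non-opioid intracellular receptor 1 (Homo sapiens) as the target, read by radioligand binding; on this read-out higher numbers stand for weaker inhibition and lower numbers for stronger inhibition. Compound 2 `CN(C)CCCCCCCOc1ccc2oc(-c3ccccc3)cc(=O)c2c1` gives 188 nM in this assay, and compound 3 `CN(C)CCCCCCCCCCOc1ccc2oc(-c3ccccc3)cc(=O)c2c1` gives 341 nM. Lengthening the chain brought a 2.1-fold lower number from compound 1 to compound 2 (0.33 log units; beyond the scatter), further lengthening gave a 1.8-fold higher number from compound 2 to compound 3 (0.26 log units; within the scatter), and the whole span is a 1.2-fold lower number from compound 1 to compound 3 (0.07 log units; within the scatter). Compound 3 thus stands second highest of the three, within the scatter of both neighbours. Compound 4 `O=c1cc(-c2ccccc2)oc2ccc(OCCCCCCN3CCCCC3)cc12` differs from compound 3 in one place: piperidin-1-yl in place of 4-(dimethylamino)butyl on a saturated chain carbon, six bonds along the chain from an oxygen on an aromatic ring. Going by the values given here, no measured step tests a ring amine; the chain-length steps were modest or within the scatter, so only a small change is expected, a 1.1-fold lower number from compound 3 to compound 4 (0.06 log units; within the scatter). Compound 4 is therefore estimated at 300 nM, between 120 nM and 750 nM.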

Compound 4, half-maximal inhibitory concentration: 54 nM
The estimate for compound 4 lay 5.6-fold (0.74 log units) above the measured number; the measured number lies below the stated range.
By their numbers in this assay, from the lowest: compound 4; then compounds 2, 3 and 1 (each within the scatter of the next, the first and the last beyond it).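

A ring amine at the chain end goes with lower numbers in this assay than any dimethylamino chain shown: a 6.3-fold lower number from compound 3 to compound 4 (0.80 log units; beyond the scatter), a 3.5-fold lower number from compound 2 to compound 4 (0.54 log units; beyond the scatter) and a 7.4-fold lower number from compound 1 to compound 4 (0.87 log units; beyond the scatter). The earlier steps shown here, all changes of chain length, gave nothing of this size. Nothing measured here explains the gain.

Compound 4 also differs in chain length from each dimethylamino compound, so the shares of ring and chain stay unseparated, and a dimethylamino group on the same chain as compound 4 would separate them. From the compounds shown here alone, whether other ring amines, such as pyrrolidine or morpholine, behave like piperidine also stays open.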